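A few compounds are considered here, and "the series" means these few. Any claim that something is new, unique, unknown or untested is made for them only; others in the source may bear on it.

Measured compounds:
Compound 1 `NS(=O)(=O)c1cc(-c2nnc(CN3CCN(c4ccc(Cl)cc4)CC3)o2)c(Cl)cc1SCc1ccccc1` gives 11000 nM in a functional assay on HeLa cells (Homo sapiens) for cytotoxicity, read by MTT assay, with a stated time of 72 h; a higher number here means a weaker inhibitor, a lower number a stronger inhibitor.
Compound 2 `NCc1nnc(-c2cc(S(N)(=O)=O)c(SCc3ccccc3)cc2Cl)o1` gives 490000 nM in this assay.

Compound 2 shows the highest of these two numbers; its nearest neighbour is compound 1, whose number lies far below it, and that gap is beyond the usual scatter. Among the measured compounds shown here, no step between two measured compounds that differ in a single place is available, so the two values can only be compared as they stand. Compound 3 `NS(=O)(=O)c1cc(-c2nnc(/C=C/c3ccc(Br)cc3)o2)c(Cl)cc1SCc1ccccc1` differs from compound 2 in one place: 2-(4-bromophenyl)ethenyl in place of aminomethyl on an aromatic carbon. Among the two measured compounds, compound 1 bears a larger group than the aminomethyl of compound 2 and gives the lower number. On that basis compound 3 is expected to move to a lower number, a step of a 33-fold lower number from compound 2 to compound 3 (1.51 log units; beyond the scatter) that should be well beyond the scatter. The estimate for compound 3 in this assay is 15000 nM, with a range from 3000 nM to 80000 nM.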

Compound 3, half-maximal inhibitory concentration: 29000 nM
Estimate against measurement, compound 3: 1.9-fold (0.29 log units) below, and the stated range covers the measured number.
By their numbers in this assay, from the lowest: compound 1; then compound 3; then compound 2.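

Read in this assay, the exchange of aminomethyl for 2-(4-bromophenyl)ethenyl on this aromatic carbon gives a 17-fold lower number from compound 2 to compound 3 (1.23 log units; beyond the scatter) and is the first single-place change available, showing directly that the number responds to the group at this position. The lower number does not require the aminomethyl group: the entering group has no hydrogen-bond donor or acceptor, while the group that leaves has one of each, and it brings a six-membered aromatic ring and a double bond outside aromatic rings. Nothing measured accounts for the size of this step.

The compounds shown leave open which part of the entering group goes with the lower number: the bromine, the double bond or the ring. A phenyl group without bromine, a saturated ethyl link to the ring, or a carboxylic acid on this carbon would help separate these parts.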